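Replacing cyclopentyl with isobutyl in the ether series

The source may hold more compounds than are shown below. What is called first, only, known or untested is meant among the compounds shown, and "the series" means these compounds.

Of the compounds shown here, three have been measured in a physicochemical assay for lipophilicity, using the shake flask method, at pH 7.4; on this read-out lower numbers stand for lower lipophilicity and higher numbers for higher lipophilicity. Compound 1 `O=C(O)CCNC(=O)c1ccc(C(Oc2ccc(-n3cc(C(F)(F)F)cn3)cc2)C2CCCC2)cc1` gives 3.3 in this assay, the highest of the three numbers. Compound 3 `CCCC(Oc1ccc(-n2cc3c(n2)CCCC3)cc1)c1ccc(C(=O)NCCC(=O)O)cc1`, the nearest, gives 2.7 in this assay, a number lower than that of compound 1 by a gap beyond the scatter. Compound 2 `CCCC(Oc1cnc(-n2cc(C(F)(F)F)cn2)nc1)c1ccc(C(=O)NCCC(=O)O)cc1`, the furthest, gives 1.5 in this assay, lower again by a gap well beyond the scatter. No two of these compounds differ in only one place, so no single step between measured compounds is available.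

Compound 4 `CC(C)CC(Oc1ccc(-n2cc(C(F)(F)F)cn2)cc1)c1ccc(C(=O)NCCC(=O)O)cc1` is not yet measured in this assay. It differs from compound 1 in one place: isobutyl in place of cyclopentyl on a saturated chain carbon bound to an aromatic carbon and an oxygen on an aromatic ring. The group that leaves and the group that enters carry no donors, no acceptors and no charge, and the rest of the molecule is kept. On that basis the step from compound 1 to compound 4 is expected to be small, at most a slight decrease and possibly none beyond the scatter, which is the change a number 0.20 log units lower from compound 1 to compound 4 (within the scatter) expresses. For compound 4 the expected value in this assay is therefore 3.1, with a range from 2.7 to 3.5.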

Compound 4, distribution coefficient: 3.2
Beside the measured number, compound 4's estimate is 0.10 log units below it; measured number inside the range.
By their numbers in this assay, from the lowest: compound 2; then compound 3; then compounds 4 and 1 (each within the scatter of the next).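

Working notes on the ether series: in this assay, the exchange of cyclopentyl for isobutyl gives the first single-place step available, a number 0.10 log units lower from compound 1 to compound 4 (within the scatter), so the two compounds cannot be told apart on this read-out. On a saturated chain carbon bound to an aromatic carbon and an oxygen on an aromatic ring, the series therefore tolerates the swap of a ring of 5 heavy atoms for an open group of 4 heavy atoms with no separable effect on the number, at least on the core of compound 1. The data at hand offer no independent measurement that would explain why this exchange leaves the two compounds indistinguishable.

Still open, from the compounds shown here alone, is how far this position stays insensitive once the entering group is of another kind, such as an amine, a hydroxyl or a longer chain such as n-hexyl, since cyclopentyl and isobutyl both carry no donors, no acceptors and no charge. Also open, going by these compounds, is whether the same exchange would read the same way on the cores of compound 2 and compound 3, as each of these differs from compound 1 and compound 4 in more than one place.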